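Side-chain hydroperoxide to hydroxy: compound 4 outlook

The source may report more compounds than this note shows. Statements on the series, on what has been measured and on what is new or still open speak of the compounds shown alone.

Measured compounds
compound 1: `CC1=CC[C@H]2[C@H](CC[C@]2(C)O)C(C)(C)[C@@H]1CC[C@H]1[C@]2(C)CC[C@H](OC(=O)c3ccc(Cl)cc3)C(C)(C)O[C@H]2CC[C@@]1(C)O`, 24100 nM
compound 2: `C=C(C)C(CC[C@@]1(C)C(CC[C@H]2[C@]3(C)CC[C@H](O)C(C)(C)O[C@H]3CC[C@@]2(C)O)=C(C)CC[C@H]1O)OO`, 31200 nM
compound 3: `CC1=C(CC[C@H]2[C@]3(C)CC[C@H](O)C(C)(C)O[C@H]3CC[C@@]2(C)O)[C@](C)(C/C=C/C(C)(C)OO)[C@H](O)CC1`, 27400 nM

In a functional assay on MCF7 cells (Homo sapiens) for antiproliferative activity, read by MTT assay, with a stated time of 72 h (on this read-out lower numbers stand for stronger inhibition and higher numbers for weaker inhibition), compound 1 gives 24100 nM, compound 2 gives 31200 nM and compound 3 gives 27400 nM. Compound 3 stands second highest of the three numbers, but its gaps to compound 1 and to compound 2 are both within the scatter, so no order among the three can be claimed. Going by the values given here, the one measured step, a 1.1-fold lower number from compound 2 to compound 3 (0.06 log units; within the scatter), swaps one chain group for another and leaves the number essentially unchanged.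

Compound 4, `CC1=C(CC[C@H]2[C@]3(C)CC[C@H](O)C(C)(C)O[C@H]3CC[C@@]2(C)O)[C@](C)(C/C=C/C(C)(C)O)[C@H](O)CC1`, differs from compound 3 by hydrogen in place of hydroxy on an oxygen on a saturated carbon. Among the compounds with values here, no measured pair shows this exact change, so the step can only be judged from the flat run of the three values, which no chain or ester variation so far has moved beyond the scatter. The step of a 1.0-fold lower number from compound 3 to compound 4 (0.01 log units; within the scatter) is therefore expected to stay within the scatter, in no particular direction. Compound 4 is estimated at 27000 nM, with a range from 12000 nM to 60000 nM.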

Compound 4, half-maximal inhibitory concentration: 21800 nM
The estimate for compound 4 lay 1.2-fold (0.09 log units) above the measured number; low and high end bracket the measured number.
By their numbers in this assay, from the lowest: compounds 4, 1, 3 and 2 (each within the scatter of the next).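

In this assay, the first change made directly at this oxygen on a saturated carbon, hydroxyoxy to hydroxy, gives a 1.3-fold lower number from compound 3 to compound 4 (0.10 log units; within the scatter), so within this chain the hydroxyoxy group is not required for a number in this range. The comparison with the other chain group gives a 1.4-fold lower number from compound 2 to compound 4 (0.16 log units; within the scatter), so the hydroxy chain also shows no step beyond the scatter against the hydroxyoxy chain of compound 2. No supporting measurement bears on why the number holds through these changes.

Going by these compounds, what an amine, a carboxylic acid or a longer chain in place of this hydroxy would do remains open, as does whether any change on this chain can move the number beyond the scatter. On these data alone, whether compound 3 and compound 4 stay this close in any other assay is also open.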